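The compounds below may be only part of what the source reports. "The series", "measured", "known", "first", "only" and "open" are said of these compounds alone.

The study gathers a few compounds around a shared core. Compound 1 `CCS(=O)(=O)Nc1cccc2c1CCCC2c1c[nH]cn1` gives 1320 nM in an assay on isolated protein (Cricetulus griseus) for binding affinity to Alpha-1B adrenergic receptor (Mesocricetus auratus), read by radioligand binding; a higher number here means a weaker inhibitor, a lower number a stronger inhibitor. Compound 2 `CCS(=O)(=O)Nc1cccc(C2CCNC2)c1` reaches only the limit < 10000 nM in this assay. Compound 3 `CCS(=O)(=O)Nc1cccc(NC2=NCCN2)c1` likewise reaches only the limit < 10000 nM in this assay, so on the numbers shown compound 3 stands at a limit and not at a number, and one further value shown is a limit as well. Within the data shown here, the one step between neighbours, a step that the two limits leave unreadable from compound 2 to compound 3, cannot be read because both ends sit at the limit of < 10000 nM in this assay, at which 2 of the 3 values shown sit. Compound 4 `CCS(=O)(=O)Nc1cccc(-c2c[nH]cn2)c1` has not yet been measured in this assay; it differs from compound 3 in that it (a group of 5 heavy atoms (3 carbon, 2 nitrogen; one five-membered aromatic ring with 2 hetero atoms) in place of a group of 6 heavy atoms (3 carbon, 3 nitrogen; one five-membered non-aromatic ring with 2 hetero atoms), on an aromatic carbon). Among the measured compounds shown here, no measured step bears on this change, since the only step available is the unreadable one already named. The imidazole group that enters is the same group that compound 1 carries, and compound 1 gives 1320 nM, so the author expects compound 4 to land in that neighbourhood. The step that this expectation means is a step that the limit leaves unreadable from compound 3 to compound 4. The estimate for compound 4 is 3000 nM, expected to fall between 800 nM and 12000 nM.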

Compound 4, inhibition constant: < 10000 nM
Compound 4: a limit, no number (the forecaster's own chance of this, stated with the estimate: 35%); the middle value lies beyond the limit too.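

Compound 4 reaches only a limit in this assay and is no number, so the steps from compound 3 to compound 4 and from compound 2 to compound 4 cannot be read, because both ends of each step sit at a limit: the limit of < 10000 nM in this assay, at which 3 of the 4 values shown sit.

The compounds shown leave open where compound 2, compound 3 and compound 4 actually lie in this assay and what 1H-imidazol-4-yl changes when it enters in place of either other group.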